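A few compounds are considered here, and "the series" means these few. Any claim that something is new, unique, unknown or untested is made for them only; others in the source may bear on it.

Measured compounds:
- compound 1 `CC(/C=N/Nc1ccc([N+](=O)[O-])cc1)=N\NC(=O)c1ccc(C(C)(C)C)cc1`: > 12000 nM
- compound 2 `CC(/C=N/Nc1ccc([N+](=O)[O-])cc1)=N\NC(=O)c1ccccc1C`: 6000 nM
- compound 3 `CC(/C=N/Nc1ccc([N+](=O)[O-])cc1)=N\NC(=O)c1ccccc1N`: 4900 nM

In a functional assay on cells (Splenocyte, Mus musculus, strain BALB/c) for inhibition, read by scintillation counting and thymidine incorporation, with a stated time of 72 h (a higher number here means a weaker inhibitor, a lower number a stronger inhibitor), compound 3 gives 4900 nM, the lowest of the two numbers shown. Compound 2 gives 6000 nM, and the step of a 1.2-fold lower number from compound 2 to compound 3 (0.09 log units; within the scatter) lies within the scatter, so the two compounds cannot be told apart. For compound 1 the assay reports only a limit, (the limit of > 12000 nM in this assay, at which 1 of the 3 values shown sits), and not a number.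

Compound 4 `COc1ccc(C(=O)N/N=C(C)/C=N/Nc2ccc([N+](=O)[O-])cc2)cc1` differs from compound 3 by 4-methoxyphenyl in place of 2-aminophenyl on a carbonyl carbon. For the measured compounds named here, no measured step exchanges groups at that part of the ring in the same way. Going by the values given here, the only measured step, a 1.2-fold lower number from compound 2 to compound 3 (0.09 log units; within the scatter), swapped one small group for another and stayed within the scatter. Compound 1, whose ring carries a tert-butyl group rather than a methoxy group, gave only a limit. Compound 4 is therefore expected to move in the direction of a higher number, a step of a 1.6-fold higher number from compound 3 to compound 4 (0.21 log units; within the scatter), with a real chance that only a limit is reported. The estimate for compound 4 is 8000 nM, between 3000 nM and 20000 nM.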

Compound 4, half-maximal inhibitory concentration: > 12000 nM
Compound 4 gave a limit, no number; the forecaster's own chance of this, stated with the estimate: 35%; middle value at least 1.5-fold (0.17 log units) away from the limit.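

In this assay compound 4 gives only a limit, not a number, the same limit as compound 1: the limit of > 12000 nM in this assay, at which 2 of the 4 values shown sit. Replacing 2-aminophenyl with 4-methoxyphenyl on the carbonyl carbon gives an at least 2.4-fold higher number from compound 3 to compound 4 (0.38 log units; beyond the scatter), so this position can show a change beyond the scatter, which the earlier swap of methyl for amino did not. The second comparison, an at least 2.0-fold higher number from compound 2 to compound 4 (0.30 log units; that floor lies within the scatter), is less firm, since its floor stays within the scatter.

As far as these compounds go, compound 1 and compound 4 both end at a limit, so the step between them cannot be read, and the true size of the other two steps remains unknown. Also open, from the compounds shown here alone, is how a carboxylic acid or a longer chain on this ring would read in place of the methoxy group.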